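Removing the 3-hydroxyphenyl from the triazole of compound 2

This account rests on a few compounds, and the source may have more. Where it says the series, first, only, none or still open, it means among the compounds named here.

Within the data shown here, compound 2 `O=C1O[C@H]([C@@H](O)Cn2cc(-c3cccc(O)c3)nn2)C(OCc2ccccc2)=C1OCc1ccccc1` is the only member of the set with a numeric result: in a functional assay on HCT-116 cells (Homo sapiens) for antiproliferative activity, read by MTT assay, with a stated time of 72 h (on this read-out higher numbers stand for weaker inhibition and lower numbers for stronger inhibition), compound 2 gives 42900 nM. Compound 1 `COc1ccc(-c2cn(C/C=C3\OC(=O)C(OCc4ccccc4)=C3OCc3ccccc3)nn2)cc1` reaches only the assay limit, compound 1 giving > 100000 nM in this assay, a limit rather than a number. Compound 3 `Cc1ccc(-c2cn(C/C=C3\OC(=O)C(OCc4ccccc4)=C3OCc3ccccc3)nn2)cc1` likewise stops at a limit, compound 3 giving > 100000 nM in this assay. Among the measured compounds shown here, the single measured step, a step that the two limits leave unreadable from compound 1 to compound 3, cannot be sized because both ends rest on (the limit of > 100000 nM in this assay, at which 2 of the 3 values shown sit). Compound 4 `O=C1O[C@H]([C@@H](O)Cn2ccnn2)C(OCc2ccccc2)=C1OCc1ccccc1` differs from compound 2 by hydrogen in place of 3-hydroxyphenyl on an aromatic carbon. For the measured compounds named here, no measured step touches this change, so no direction is given by the data. Compound 4 is expected to move by a 1.6-fold higher number from compound 2 to compound 4 (0.21 log units; within the scatter). Compound 4 is therefore estimated at 70000 nM, between 25000 nM and 200000 nM in this assay.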

Compound 4, half-maximal inhibitory concentration: > 100000 nM
Compound 4 gave a limit, no number; the forecaster's own chance of this, stated with the estimate: 45%; middle value at least 1.4-fold (0.15 log units) away from the limit.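

In this assay compound 4 stops at a limit, > 100000 nM, not a number. Even so, hydrogen in place of 3-hydroxyphenyl gives an at least 2.3-fold higher number from compound 2 to compound 4 (0.36 log units; beyond the scatter), the first readable step in the series, so the group on this aromatic carbon of the five-membered ring counts for compound 2. Most of the set still gives no number: the limit of > 100000 nM in this assay, at which 3 of the 4 values shown sit.

As far as these compounds go, whether the step belongs to the hydroxyl or to the phenyl ring stays open. So does the effect of an aminophenyl or a carboxylic acid at this carbon.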